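This account rests on a few compounds, and the source may have more. Where it says the series, first, only, none or still open, it means among the compounds named here.

The measured compounds:
compound 1 `CSc1nc(Nc2ccc(C(F)(F)F)c(Cl)c2)c2nc(Nc3c(Cl)cccc3Cl)sc2n1` — in a functional assay on HEK293 cells for antagonist activity at transient receptor potential cation channel subfamily V member 1 (Homo sapiens), read by calcium flux (on this read-out lower numbers stand for stronger inhibition and higher numbers for weaker inhibition), compound 1 gives 224 nM
compound 2 `FC(F)(F)c1ccc(Nc2nc(N3CCC3)nc3sc(Nc4c(Cl)cccc4Cl)nc23)cc1` — in this assay compound 2 gives 59 nM

Of the compounds shown here, two sharing one core have been measured. Compound 2 has the lower of the two numbers, and its gap to compound 1 lies beyond the scatter, so compound 2 is the stronger inhibitor of the pair. The two differ in more than one place, so no single change can be singled out from their values alone.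

Compound 3 `CC(C)N1CCN(c2nc(Nc3ccc(C(F)(F)F)cc3)c3nc(Nc4c(Cl)cccc4Cl)sc3n2)CC1` is not yet measured. It keeps the core and the other groups of compound 2 and differs from it in one place: 4-isopropylpiperazin-1-yl in place of azetidin-1-yl on an aromatic carbon. For the measured compounds named here, no measured pair shows a change of this kind, so the expectation rests only on compound 2. The step in this assay is expected to be small, a 1.4-fold higher number from compound 2 to compound 3 (0.13 log units; within the scatter), with no clear direction beyond the scatter. Compound 3 is therefore estimated at 80 nM, within a range of 20 nM to 300 nM.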

Compound 3, half-maximal inhibitory concentration: 184 nM
Compound 3: the middle estimate sits 2.3-fold (0.36 log units) below what was measured; measured number inside the range.
By their numbers in this assay, from the lowest: compound 2; then compounds 3 and 1 (each within the scatter of the next).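

In this assay, putting 4-isopropylpiperazin-1-yl in place of azetidin-1-yl on the aromatic carbon between two ring nitrogen atoms gives a 3.1-fold higher number from compound 2 to compound 3 (0.49 log units; beyond the scatter), a modest weakening that lies beyond the scatter. For the compounds shown here, until now no pair differed in one place only, so this is the first direct sign that inhibition responds to the group at this position. The much larger group costs some inhibition but does not remove it, and nothing measured here says why the number moved. With only these two groups compared, the step cannot be assigned to the ring size, the second ring nitrogen or the isopropyl group. Piperazin-1-yl without the isopropyl, or pyrrolidin-1-yl, at the same position would help tell these apart.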